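Formyl in place of methyl on the benzyl-bearing core

A few compounds are considered here, and "the series" means these few. Any claim that something is new, unique, unknown or untested is made for them only; others in the source may bear on it.

Compound 1 `O=Cc1ccc(-c2cn3ccnc3c(-c3ccc4ncn(C5CCCCC5)c4c3)n2)cc1` and compound 2 `Cc1cccc(-c2cn3ccnc3c(-c3ccc4ncn(Cc5ccccc5)c4c3)n2)c1` were both tested in a functional assay on DU-145 cells (Homo sapiens) for inhibition, read by sulforhodamine B assay, with a stated time of 48 h, tested at 10 uM; on this read-out higher numbers stand for more inhibition at the one concentration tested (going by the name of the read-out) and lower numbers for less inhibition. In this assay compound 1 gives 24.3%, whereas compound 2 gives 14.2%, the lower of the two numbers, a gap beyond the scatter. Compound 3 `O=Cc1ccc(-c2cn3ccnc3c(-c3ccc4ncn(Cc5ccccc5)c4c3)n2)cc1` is reached from compound 2 by 4-formylphenyl in place of 3-methylphenyl on an aromatic carbon, so that it now carries the same 4-formylphenyl as compound 1. Going by the values given here, no measured step isolates this change. Compound 3 is expected to move upward by a number 5.8 percentage points higher from compound 2 to compound 3 (within the scatter) in this assay, since compound 1 with the same group reaches 24.3%. Compound 3 is estimated at 20%, within 6% to 36%.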

Compound 3, a percentage reported as inhibition, at one concentration (the size of the read-out at that concentration, not a potency): 24.3%
Estimate against measurement, compound 3: 4.3 percentage points below, within the range that was stated.
By their numbers in this assay, from the lowest: compound 2; then compounds 1 and 3 (each within the scatter of the next).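

In this assay, 4-formylphenyl in place of 3-methylphenyl on this aromatic carbon gives a number 10.1 percentage points higher from compound 2 to compound 3 (beyond the scatter), a comparison of the two groups in one place. With 4-formylphenyl present, benzyl in place of cyclohexyl on the aromatic nitrogen gives no change at the digits printed from compound 1 to compound 3 (within the scatter), so these two nitrogen groups cannot be told apart here. Nothing at hand explains either step. From the compounds shown here alone, whether the formyl group itself or its placement on the phenyl ring carries the step stays open. Going by these compounds, how a carboxylic acid or an amine in its stead would read in this assay also stays open.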